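This account rests on a few compounds, and the source may have more. Where it says the series, first, only, none or still open, it means among the compounds named here.

Measured so far in an assay on isolated protein for binding affinity to Bombesin receptor subtype-3 (Homo sapiens); a higher number here means a weaker inhibitor, a lower number a stronger inhibitor:
compound 1, `CCC(C)(C)Cc1c[nH]c(CCc2ccc(-c3ccccc3OCc3ncn[nH]3)cc2)n1`: 22 nM
compound 2, `CCC(C)(C)Cc1c[nH]c(CCc2ccc(-c3ccccc3OCc3nc(=O)[nH][nH]3)cc2)n1`: 31 nM

Compound 1 and compound 2 share the same core and differ only in the small aromatic ring that hangs on a saturated chain carbon bound to an oxygen on an aromatic ring. On the numbers at hand compound 2 sits close to compound 1: the step of a 1.4-fold higher number from compound 1 to compound 2 (0.15 log units; within the scatter) is the only one measured so far, and it is small. Compound 3, `CCC(C)(C)Cc1c[nH]c(CCc2ccc(-c3ccccc3OCc3cnn[nH]3)cc2)n1`, keeps everything else in place and once more swaps this ring: a group of 5 heavy atoms (2 carbon, 3 nitrogen; one five-membered aromatic ring with 3 hetero atoms) in place of a group of 6 heavy atoms (2 carbon, 3 nitrogen, 1 oxygen; one five-membered aromatic ring with 3 hetero atoms), on a saturated chain carbon bound to an oxygen on an aromatic ring. Among the measured compounds shown here, the one measured step bears directly on this change, since it is likewise a swap of the ring at this place and it stayed within the scatter. A step of similar size is therefore expected from compound 2 to compound 3 in this assay, or none beyond the scatter, a 1.2-fold lower number from compound 2 to compound 3 (0.09 log units; within the scatter). Compound 3 is expected to give 25 nM in this assay, with a range from 10 nM to 60 nM.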

Compound 3, half-maximal inhibitory concentration: 83 nM
For compound 3 the middle estimate is 3.3-fold (0.52 log units) below the measured one, outside the stated range (above it).
By their numbers in this assay, from the lowest: compounds 1 and 2 (each within the scatter of the next); then compound 3.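

In this assay, the ring on this saturated chain carbon proves not to be freely interchangeable: swapping it gives a 2.7-fold higher number from compound 2 to compound 3 (0.43 log units; beyond the scatter) and, against the closest match, a 3.8-fold higher number from compound 1 to compound 3 (0.58 log units; beyond the scatter) as well. The second step is the cleaner comparison, as 1H-1,2,3-triazol-5-yl and 1H-1,2,4-triazol-5-yl are both triazole rings built from the same atoms and differ only in how those atoms are arranged, so arrangement alone is enough to move the number beyond the scatter, which the earlier step between compound 1 and compound 2 gave no sign of. Nothing available here explains this difference between the two rings.

Every group shown at this place is a five-membered aromatic ring with 3 hetero atoms, so how a tetrazole, an imidazole or an open-chain carboxylic acid would compare remains open. Also open, from the compounds shown here alone, is whether the gap between the two triazoles would persist if the 2,2-dimethylbutyl-type chain on the shared core were replaced by a shorter chain.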